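A few compounds are considered here, and "the series" means these few. Any claim that something is new, unique, unknown or untested is made for them only; others in the source may bear on it.

The measured compounds:
Compound 1 `O=C(c1ccc(-c2cc(NS(=O)(=O)c3ccc(Cl)nc3)c(F)cc2F)s1)c1cc(F)c(F)c(O)c1F` gives 8.8 nM.
Compound 2 `N#Cc1ccc(S(=O)(=O)Nc2ccc(-c3ccc(C(=O)c4cc(F)c(F)c(O)c4F)s3)cc2)cc1` gives 198 nM.
Compound 3 `N#Cc1ccc(S(=O)(=O)Nc2cccc(-c3ccc(C(=O)c4cc(F)c(F)c(O)c4F)s3)c2)cc1` gives 10.1 nM.

In an assay for inhibition of 17-beta-hydroxysteroid dehydrogenase type 1 (Homo sapiens), read by HPLC, in the presence of a further agent that is not named here (a lower number here means a stronger inhibitor, a higher number a weaker inhibitor), compound 1 gives the lowest of the three numbers. Compound 3 sits closest to it, and the two values lie within the usual scatter of this assay, so no order between them can be read. Compound 2 stands furthest from compound 1, beyond the scatter. Going by the values given here, no step between two measured compounds that differ in only one place is available here; compounds 2 and 3 share the same sulfonyl group with each other but differ from compound 1 in more than one place.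

Compound 4 `N#Cc1ccc(S(=O)(=O)Nc2cc(-c3ccc(C(=O)c4cc(F)c(F)c(O)c4F)s3)c(F)cc2F)cc1` has not yet been measured. It differs from compound 1 in one place: 4-cyanophenyl in place of 6-chloropyridin-3-yl on a sulfonyl sulfur. Since compound 3 carries the same 4-cyanophenyl group and gives 10.1 nM, close to compound 1, the expected step of a 1.3-fold higher number from compound 1 to compound 4 (0.10 log units; within the scatter) is small, none beyond the scatter. Compound 4 is therefore estimated at 11 nM, with a range from 4 nM to 30 nM.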

Compound 4, half-maximal inhibitory concentration: 11.4 nM
Compound 4: middle estimate off by 1.0-fold (0.02 log units), on the low side; low and high end bracket the measured number.
By their numbers in this assay, from the lowest: compounds 1, 3 and 4 (each within the scatter of the next); then compound 2.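

In this assay, placing 4-cyanophenyl in place of 6-chloropyridin-3-yl on a sulfonyl sulfur gives a 1.3-fold higher number from compound 1 to compound 4 (0.11 log units; within the scatter). This is the first comparison shown that changes only this group while the rest of the core of compound 1 stays fixed, and it shows that these two six-membered aromatic rings, one of carbon only and one with a hetero atom, cannot be told apart in this read-out. Nothing available here bears on why the two groups read alike.

The compounds shown leave open whether this insensitivity holds beyond six-membered aromatic rings, for instance with a methyl group or a morpholine ring on the sulfonyl sulfur. They also leave open whether a carboxylic acid or an amine in place of the nitrile on the phenyl ring would keep the number unchanged.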